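Carbonyl substituent change from compound 2 to compound 3

A few compounds are considered here, and "the series" means these few. Any claim that something is new, unique, unknown or untested is made for them only; others in the source may bear on it.

Among the compounds with values here, in a physicochemical assay for lipophilicity, read by HPLC, at pH 7.5 (on this read-out higher numbers stand for higher lipophilicity and lower numbers for lower lipophilicity), compound 1 `CCc1cc(CC)n2nc(-c3ccc(OC)cc3)c(CC(=O)N(CC)C(C)(C)C)c2n1` reads 3.32 and compound 2 `CCc1cc(CC)n2nc(-c3ccc(OC)cc3)c(CC(=O)N(C(C)CC)C(C)CC)c2n1` reads 3.75, the higher of the two numbers so far. Compound 3 `CCc1cc(CC)n2nc(-c3ccc(OC)cc3)c(CC(=O)N(C)c3ccccc3)c2n1` keeps the shared core and differs from compound 2 at one place: methyl(phenyl)amino in place of bis(sec-butyl)amino on a carbonyl carbon. Methyl(phenyl)amino thus stands in place of bis(sec-butyl)amino on a carbonyl carbon.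

Within the data shown here, only one measured step bears on this change: a number 0.43 log units higher from compound 1 to compound 2 (beyond the scatter). It is modest, and there the larger of the two groups on the carbonyl carbon goes with the higher number. The entering group in compound 3 is smaller than the one it replaces, which points to a lower number. However, neither measured compound carries a ring in this place, so the step offers only a rough guide to size and direction.

A fall of similar or slightly larger size, beyond the scatter, is expected in this assay. The estimated step is a number 0.55 log units lower from compound 2 to compound 3 (beyond the scatter). For compound 3 the estimated value is 3.2, with an expected range from 2.8 to 3.6.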

Compound 3, partition coefficient: 3.11
For compound 3 the middle estimate is 0.09 log units above the measured one, and the stated range covers the measured number.
By their numbers in this assay, from the lowest: compounds 3 and 1 (each within the scatter of the next); then compound 2.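

In this assay, the position on the carbonyl carbon now includes a group with a ring: methyl(phenyl)amino in place of bis(sec-butyl)amino gives a number 0.64 log units lower from compound 2 to compound 3 (beyond the scatter). This change comes with no difference in hydrogen-bond donor count, hydrogen-bond acceptor count or net charge, as both groups have 0 donors, 0 acceptors and no net charge. The other new pair gives a number 0.21 log units lower from compound 1 to compound 3 (within the scatter), so the two compounds do not separate even though compound 3 carries the group with more heavy atoms, and compound 3 therefore goes against any simple rise in the number with heavy-atom count across these three compounds.

No measurement at hand explains the size of either step or separates the contribution of the phenyl ring from that of the other parts of the group. Also open, going by these compounds, is how the number would respond to a morpholine or piperidine ring on the carbonyl carbon, or to a pyridine ring in place of the phenyl ring in methyl(phenyl)amino.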